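Sulfonyl aryl variation in a sulfonamide series

This account rests on a few compounds, and the source may have more. Where it says the series, first, only, none or still open, it means among the compounds named here.

Measured so far:
compound 1 `COc1cc(C)cc(Cl)c1S(=O)(=O)Nc1ccc(Nc2nc(C)cc(Nc3ccc(F)cc3)n2)cc1` — > 50000 nM
compound 2 `COc1ccc(Nc2cc(C)nc(Nc3ccc(NS(=O)(=O)c4ccccc4Cl)cc3)n2)cc1` — > 50000 nM

In a functional assay on MCF7 cells (Homo sapiens) for antiproliferative activity, read by MTT assay (a lower number here means a stronger inhibitor, a higher number a weaker inhibitor), compound 2 gives > 50000 nM, which is a limit of the assay and not a number. Compound 1 likewise gives > 50000 nM in this assay, again a limit only. Both values shown therefore sit at the limit of > 50000 nM in this assay, at which 2 of the 2 values shown sit, and compound 2 stands at that limit with no measured neighbour to rank it against; no order between compound 1 and compound 2 can be read from these two limits.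

Compound 3 `COc1ccc(Nc2cc(C)nc(Nc3ccc(NS(=O)(=O)c4c(Cl)cc(C)cc4OC)cc3)n2)cc1` remains to be measured. It differs from compound 2 in one place: 2-chloro-6-methoxy-4-methylphenyl in place of 2-chlorophenyl on a sulfonyl sulfur. Going by the values given here, no measured step between single-change neighbours exists in this set, so the size of the step has to be judged from the limits alone. Compound 1 carries the same 2-chloro-6-methoxy-4-methylphenyl group on its sulfonyl sulfur and reaches only the limit, so the change is not expected to move compound 3 beyond the scatter; the expected step from compound 2 to compound 3 is a number no higher from compound 2 to compound 3 (the limit leaves the size open), essentially none. Compound 3 is estimated at 50000 nM, with a range from 15000 nM to 150000 nM, most probably reported again as a limit.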

Compound 3, half-maximal inhibitory concentration: > 50000 nM
Compound 3 ended at the assay's limit; the forecaster's own chance of this, stated with the estimate: 80%; the middle value sits exactly at the limit.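

In this assay compound 3 gives > 50000 nM, a limit of the assay. No step can be read from compound 2 to compound 3 or from compound 1 to compound 3, with all three compounds resting at one limit: the limit of > 50000 nM in this assay, at which 3 of the 3 values shown sit.

The compounds shown leave open whether either change, on the sulfonyl aryl group or methoxy in place of fluoro, alters activity in this assay at all.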